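The source may report more compounds than this note shows. Statements on the series, on what has been measured and on what is new or still open speak of the compounds shown alone.

Compound 1 `Cc1ccccc1C(=O)N(C)c1ccc(C(O)(C(F)(F)F)C(F)(F)F)cc1`: 38000 nM
Compound 2 `CN(c1ccc(C(O)(C(F)(F)F)C(F)(F)F)cc1)S(=O)(=O)c1cccc(F)c1`: 19000 nM

In an ADME assay on Li23 cells (Homo sapiens) for cytotoxicity, read by WST assay (on this read-out lower numbers stand for higher toxicity in this test and higher numbers for lower toxicity in this test), compound 1 gives 38000 nM and compound 2 gives 19000 nM; the two numbers lie within the usual scatter of each other, so compound 1 cannot be set apart from compound 2 on these figures. Compound 3 `CN(C(=O)Nc1ccccc1)c1ccc(C(O)(C(F)(F)F)C(F)(F)F)cc1` has not been measured. It differs from compound 1 by anilino in place of 2-methylphenyl on a carbonyl carbon. Among the measured compounds shown here, with no step between measured compounds beyond the scatter, the step of a 1.2-fold lower number from compound 1 to compound 3 (0.06 log units; within the scatter) is expected to stay within the scatter, in no clear direction. Compound 3 is therefore estimated at 33000 nM in this assay, with a range from 13000 nM to 85000 nM.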

Compound 3, half-maximal cytotoxic concentration: > 20000 nM
Compound 3 ended at the assay's limit (the forecaster's own chance of this, stated with the estimate: 15%); the middle value does not contradict the limit.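

Among the compounds shown here, compound 3 reads > 20000 nM, which is a limit of the assay and not a number, so no step from compound 1 to compound 3 can be read. The compounds shown leave open whether anilino in place of 2-methylphenyl on a carbonyl carbon changes the half-maximal cytotoxic concentration at all.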